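The source may hold more compounds than are shown below. What is called first, only, known or untested is meant among the compounds shown, and "the series" means these compounds.

In an ADME assay on MT4 cells (Homo sapiens) for cytotoxicity, read by MTT assay, with a stated time of 4 days (on this read-out lower numbers stand for higher toxicity in this test and higher numbers for lower toxicity in this test), compound 2 `Cc1cccc(C)c1Oc1nc(Nc2ccc(C#N)cc2)nc2ccccc12` gives 35000 nM, the highest of the three numbers; compound 1 `Cc1cc(Br)c(Oc2nc(Nc3ccc(C#N)cc3)nc3ccccc23)c(Br)c1` gives 25000 nM, the nearest to it, and compound 3 `CCCOc1cc(C#N)cc(OC)c1Oc1nc(Nc2ccc(C#N)cc2)nc2ccccc12` gives 5200 nM, the furthest from it. Compound 4 `N#Cc1ccc(Nc2nc(Oc3c(Cl)cc(Cl)cc3Cl)c3ccccc3n2)cc1` is still to be measured in this assay; its change from compound 2 is 2,4,6-trichlorophenyl in place of 2,6-dimethylphenyl on an oxygen on an aromatic ring. Within the data shown here, the one measured step that bears on this exchange is a 1.4-fold higher number from compound 1 to compound 2 (0.15 log units; within the scatter), which swaps 2,6-dibromo-4-methylphenyl for 2,6-dimethylphenyl on the same oxygen and stays within the scatter. No step beyond the scatter is therefore expected in this assay for compound 4, whose number is estimated at 25000 nM (range 10000 nM to 60000 nM). The expected step is a 1.4-fold lower number from compound 2 to compound 4 (0.15 log units; within the scatter).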

Compound 4, half-maximal cytotoxic concentration: 56000 nM
Beside the measured number, compound 4's estimate is 2.2-fold (0.35 log units) below it, within the range that was stated.
By their numbers in this assay, from the lowest: compound 3; then compounds 1, 2 and 4 (each within the scatter of the next, the first and the last beyond it).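

This position takes 2,4,6-trichlorophenyl as readily as 2,6-dimethylphenyl: this assay shows a 1.6-fold higher number from compound 2 to compound 4 (0.20 log units; within the scatter) with no real separation between the two groups. Among these compounds, replacing 2,6-dibromo-4-methylphenyl gives a 2.2-fold higher number from compound 1 to compound 4 (0.35 log units; beyond the scatter) and is the only step at this position that clears the scatter, though modestly. No measured evidence accounts for either step.

Open, as far as these compounds go, is whether a phenyl group carrying an amine or a carboxylic acid would stay in this range, and which of the propoxy, nitrile and methoxy groups of compound 3 goes with its lower number.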